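One Methoxy Less: From Compound 2 to Compound 3

The compounds below may be only part of what the source reports. "The series", "measured", "known", "first", "only" and "open" are said of these compounds alone.

compound 1, `Nc1cc(N)c2nc(-c3ccccc3)c(NCc3ccc(Cl)c(Cl)c3)nc2c1`: 1950 nM
compound 2, `COc1cc(CNc2nc3cc(N)cc(N)c3nc2-c2ccccc2)cc(OC)c1OC`: 9120 nM

Two compounds sharing one core were measured in a functional assay on IGROV-1 cells (Homo sapiens) for inhibition, read by sulforhodamine B assay, with a stated time of 48 h; a higher number here means a weaker inhibitor of growth, a lower number a stronger inhibitor of growth. Compound 2 gives 9120 nM, the higher of the two numbers. Going by the values given here, its only measured neighbour, compound 1, gives 1950 nM, and the gap between the two lies beyond the scatter.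

Compound 3, `COc1ccc(CNc2nc3cc(N)cc(N)c3nc2-c2ccccc2)cc1OC`, differs from compound 2 in a single place: hydrogen in place of methoxy on an aromatic carbon. Among the compounds with values here, no pair of measured compounds shows the effect of such a change, so the expectation for compound 3 rests on compound 2 alone. A small step from compound 2 toward a lower number in this assay is expected, a 1.5-fold lower number from compound 2 to compound 3 (0.18 log units; within the scatter), but not one that would clearly exceed the scatter. Compound 3 is therefore estimated at 6000 nM, with a range from 2500 nM to 15000 nM.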

Compound 3, concentration for 50% growth inhibition: 11500 nM
Beside the measured number, compound 3's estimate is 1.9-fold (0.28 log units) below it; the range from low to high includes it.
By their numbers in this assay, from the lowest: compound 1; then compounds 2 and 3 (each within the scatter of the next).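

In this assay, hydrogen in place of methoxy on this aromatic carbon, ortho to a methoxy group, gives a 1.3-fold higher number from compound 2 to compound 3 (0.10 log units; within the scatter) and so leaves the number within the scatter at this position. Compound 3 also allows a comparison in one place with compound 1: 3,4-dimethoxyphenyl in place of 3,4-dichlorophenyl gives a 5.9-fold higher number from compound 1 to compound 3 (0.77 log units; beyond the scatter), a step that lies beyond the scatter, so this exchange separates the two compounds in a way the loss of one methoxy does not. No measurement at hand offers an explanation for either step.

The compounds shown leave open whether a different group on this aromatic carbon, such as a hydroxyl, an amine or a single chlorine, would move the number beyond the scatter. They also leave open whether hydrogen in place of a second methoxy would do so.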